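Amide-side variation on the shared core: compound 4

The compounds below may be only part of what the source reports. "The series", "measured", "known", "first", "only" and "open" are said of these compounds alone.

Three measured compounds share one core and differ only in the amide portion. Compound 1 `CCCN(CC1CCOC1)C(=O)c1cc(OC)c2oc(NCc3cccc(Cl)c3)nc2c1` gives 12 nM in an assay on isolated protein for inhibition of thyroid hormone receptor beta (Homo sapiens), read by fluorescence, with a stated time of 30 min; a higher number here means a weaker inhibitor, a lower number a stronger inhibitor. Compound 2 `COc1cc(C(=O)N2CC[C@@H](O)C(C)(C)C2)cc2nc(NCc3cccc(Cl)c3)oc12` gives 35 nM in this assay, and compound 3 `COc1cc(C(=O)N2CC(C)C(O)CC2C2CC2)cc2nc(NCc3cccc(Cl)c3)oc12` gives 8 nM in this assay. Compound 3 carries the lowest number of the three: there is a 1.5-fold lower number from compound 1 to compound 3 (0.18 log units; within the scatter) and a 4.4-fold lower number from compound 2 to compound 3 (0.64 log units; beyond the scatter), while a 2.9-fold higher number from compound 1 to compound 2 (0.46 log units; beyond the scatter) separates the other two. Compound 4 `COc1cc(C(=O)N2CC(C)C(O)CC2CCO)cc2nc(NCc3cccc(Cl)c3)oc12` differs from compound 3 by 2-hydroxyethyl in place of cyclopropyl on a saturated ring carbon. Among the measured compounds shown here, no measured step alters a single substituent on this ring; the steps seen so far each replace the whole amine portion, and all of them stay within a modest band, so a shift of comparable size in this assay is the most that can be expected here, in either direction. On that basis compound 4 is expected to come out slightly weaker than compound 3, a 1.9-fold higher number from compound 3 to compound 4 (0.27 log units; within the scatter), with the step likely inside or only just beyond the scatter. The estimate for compound 4 in this assay is 15 nM, with a range from 5 nM to 45 nM.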

Compound 4, half-maximal inhibitory concentration: 0.27 nM
Beside the measured number, compound 4's estimate is 56-fold (1.74 log units) above it; measured number outside the range, below it.
By their numbers in this assay, from the lowest: compound 4; then compounds 3 and 1 (each within the scatter of the next); then compound 2.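

On the saturated ring carbon next to the ring nitrogen, 2-hydroxyethyl in place of cyclopropyl gives a 30-fold lower number from compound 3 to compound 4 (1.47 log units; beyond the scatter) in this assay, showing that one substituent at this position can move the number further than any whole-amine replacement among compound 1, compound 2 and compound 3. The 4-hydroxy-2-(2-hydroxyethyl)-5-methylpiperidin-1-yl amide also stands clear of the other two amine portions, with a 130-fold lower number from compound 2 to compound 4 (2.11 log units; beyond the scatter) and with a 44-fold lower number from compound 1 to compound 4 (1.65 log units; beyond the scatter) as well. Nothing available explains the size of this step.

From the compounds shown here alone, whether the change depends on the terminal hydroxy group or on the open chain itself remains open; 2-methoxyethyl, 3-hydroxypropyl or 2-aminoethyl at this carbon would separate these readings. Going by these compounds, the structures of compound 3 and compound 4 also leave the stereochemistry of this ring undefined, so its contribution remains unknown.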